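The source may report more compounds than this note shows. Statements on the series, on what has been measured and on what is new or still open speak of the compounds shown alone.

Three compounds have been measured in a physicochemical assay for solubility, read by HPLC; a lower number here means a less soluble compound, a higher number a more soluble compound:

- compound 1, `O=C(c1ccc(Cl)cc1)N1CCN(c2nc(=O)c3cc(C(F)(F)F)cc([N+](=O)[O-])c3s2)CC1`, gives 5.19 ug/mL
- compound 2, `CCC(=O)N1CCN(c2nc(=O)c3cc(C(F)(F)F)cc([N+](=O)[O-])c3s2)CC1`, gives 3.29 ug/mL
- compound 3, `O=c1nc(N2CCN(CC3CCCCC3)CC2)sc2c([N+](=O)[O-])cc(C(F)(F)F)cc12`, gives 9.07 ug/mL

Compound 3 holds the highest of the three numbers, though not by much: the step of a 1.7-fold higher number from compound 1 to compound 3 (0.24 log units; within the scatter) stays within the scatter, while the step of a 2.8-fold higher number from compound 2 to compound 3 (0.44 log units; beyond the scatter) reaches beyond it. The step of a 1.6-fold lower number from compound 1 to compound 2 (0.20 log units; within the scatter) is also within the scatter.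

Compound 4, `CCCC(=O)N1CCN(c2nc(=O)c3cc(C(F)(F)F)cc([N+](=O)[O-])c3s2)CC1`, differs from compound 3 in one place: propylcarbonyl in place of cyclohexylmethyl on an amine nitrogen in a ring. The step that bears most directly on this change runs the other way, from propanoyl to cyclohexylmethyl on the same ring nitrogen, and was a 2.8-fold higher number from compound 2 to compound 3 (0.44 log units; beyond the scatter); compound 4 carries a propylcarbonyl, a chain only one carbon longer than the propanoyl of compound 2. The change from compound 3 to compound 4 should therefore roughly undo that step, giving a modest drop in this assay. For compound 4 the expected step is a 2.3-fold lower number from compound 3 to compound 4 (0.36 log units; beyond the scatter). Compound 4 is estimated to give about 4 ug/mL, within a range of 2 ug/mL to 8 ug/mL.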

Compound 4, solubility: 2.46 ug/mL
Compound 4: the middle estimate sits 1.6-fold (0.21 log units) above what was measured; the measured number falls inside the stated range.
By their numbers in this assay, from the lowest: compounds 4, 2, 1 and 3 (each within the scatter of the next, the first and the last beyond it).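

In this assay, the direct swap of cyclohexylmethyl for propylcarbonyl on the amine nitrogen in the ring gives a 3.7-fold lower number from compound 3 to compound 4 (0.57 log units; beyond the scatter), which confirms from a second amide that this position can shift the number beyond the scatter. Lengthening the chain on the carbonyl by one methyl gives a 1.3-fold lower number from compound 2 to compound 4 (0.13 log units; within the scatter), so this small extension does not separate the two amides. Propyl in place of 4-chlorophenyl on the carbonyl carbon gives a 2.1-fold lower number from compound 1 to compound 4 (0.32 log units; beyond the scatter), a step beyond the scatter, whereas the ethyl replacement in compound 2 stayed within it.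

Nothing available here explains these differences.

On these data alone, it remains open how a longer chain on the carbonyl, or an amine or a carboxylic acid at the end of that chain, would change the number.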